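The source may hold more compounds than are shown below. What is called first, only, known or untested is meant among the compounds shown, and "the series" means these compounds.

Measured so far, in a functional assay on SNB-19 cells (Homo sapiens) for antiproliferative activity, with a stated time of 48 h; a higher number here means a weaker inhibitor of growth, a lower number a stronger inhibitor of growth:
Compound 1 `Cc1cc(O)c(C2=NN(c3ccc(S(N)(=O)=O)cc3)C(c3ccccc3O)C2)cc1Cl` gives 15200 nM.
Compound 2 `Cc1cc(O)c(C2=NN(c3ccc(S(N)(=O)=O)cc3)C(/C=C/c3ccccc3)C2)cc1Cl` gives 19900 nM.

Compound 2 and compound 1 are within the scatter of each other in this assay, as the step of a 1.3-fold higher number from compound 1 to compound 2 (0.12 log units; within the scatter) shows. Compound 3 `COc1ccc(C2CC(c3cc(Cl)c(C)cc3O)=NN2c2ccc(S(N)(=O)=O)cc2)c(OC)c1OC` differs from compound 2 by 2,3,4-trimethoxyphenyl in place of 2-phenylethenyl on a saturated ring carbon. Within the data shown here, the one step measured, a 1.3-fold higher number from compound 1 to compound 2 (0.12 log units; within the scatter), also exchanged the group on that saturated ring carbon and stayed within the scatter, so no step beyond the scatter is expected here either. Compound 3 is expected at 15000 nM, with a range from 5000 nM to 45000 nM. The expected step is a 1.3-fold lower number from compound 2 to compound 3 (0.12 log units; within the scatter).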

Compound 3, concentration for total growth inhibition: 23900 nM
For compound 3 the middle estimate is 1.6-fold (0.20 log units) below the measured one, within the range that was stated.
By their numbers in this assay, from the lowest: compounds 1, 2 and 3 (each within the scatter of the next).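

In this assay, 2,3,4-trimethoxyphenyl on the saturated ring carbon stays within the scatter of both earlier groups, with a 1.2-fold higher number from compound 2 to compound 3 (0.08 log units; within the scatter) and a 1.6-fold higher number from compound 1 to compound 3 (0.20 log units; within the scatter). This position therefore accepts a group of 12 heavy atoms with 3 hydrogen-bond acceptors, in place of the 8 heavy atoms of 2-phenylethenyl, without a step beyond the scatter. Nothing available explains this result.

Going by these compounds, all three groups here carry a six-membered aromatic ring of carbon only, so the effect of an amine, a carboxylic acid or a plain alkyl chain at this carbon remains open. On these data alone, whether any group at this position can produce a step beyond the scatter also remains open.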